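The compounds below may be only part of what the source reports. "The series", "measured", "known", "first", "only" and "open" are said of these compounds alone.

Measured so far in a functional assay on cells (Splenocyte, Mus musculus, strain BALB/c) for inhibition, read by scintillation counting and thymidine incorporation, with stated times of 48 h and 8 h; a higher number here means a weaker inhibitor, a lower number a stronger inhibitor:
- compound 1 `COc1cccc(-c2nc(Cc3c[nH]c4ccccc34)no2)c1` gives 11100 nM
- compound 2 `COc1ccc(-c2nc(Cc3c[nH]c4ccccc34)no2)cc1` reaches only a limit, > 50000 nM, so no number is known for it
- compound 3 `COc1ccc(-c2nc(Cc3c[nH]c4ccccc34)no2)c(OC)c1` gives 4700 nM

Compound 4 `COc1cc(OC)cc(-c2nc(Cc3c[nH]c4ccccc34)no2)c1` has not yet been measured in this assay. It differs from compound 1 by methoxy in place of hydrogen on an aromatic carbon. The same kind of change separates compound 2 from compound 3, (methoxy in place of hydrogen on an aromatic carbon); the surroundings differ, as the entering group sits ortho to a large group in compound 3 but meta to a large group in compound 4. That earlier change gave an at least 10-fold lower number from compound 2 to compound 3 (1.02 log units; beyond the scatter). Compound 1 and compound 2 share the same atoms joined differently; this difference between the cores is not broken down here. Resting on the step of an at least 10-fold lower number from compound 2 to compound 3 (1.02 log units; beyond the scatter), a smaller gain is expected for compound 4, about a 2.8-fold lower number from compound 1 to compound 4 (0.44 log units; beyond the scatter). Compound 4 is therefore estimated at 4000 nM, between 1500 nM and 12000 nM.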

Compound 4, half-maximal inhibitory concentration: 13900 nM
Compound 4: the middle estimate sits 3.5-fold (0.54 log units) below what was measured; the measured number lies above the stated range.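

In this assay, methoxy in place of hydrogen on the core of compound 1 gives a step that stays within the scatter: a 1.3-fold higher number from compound 1 to compound 4 (0.10 log units; within the scatter). The large gain seen on the other core therefore does not carry over to this one, and the two steps clearly differ: the same change on two cores in this assay, an at least 10-fold lower number (1.02 log units; beyond the scatter) from compound 2 to compound 3 and a 1.3-fold higher number (0.10 log units; within the scatter) from compound 1 to compound 4, at least 13-fold (1.12 log units) apart, beyond the scatter of two such steps. This does not show the true size of the earlier step, as compound 2 stands only at a limit, nor does one pair of steps give a rule for other cores: the limit of > 50000 nM in this assay, at which 1 of the 4 values shown sits.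

On these data alone, it remains open how much the outcome depends on where the methoxy group stands on the ring. As far as these compounds go, it is also open whether an amine, a hydroxyl group or a carboxylic acid in its place would behave alike on both cores.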